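This account rests on a few compounds, and the source may have more. Where it says the series, first, only, none or still open, it means among the compounds named here.

Measured so far:
- compound 1, `COc1cc(N2C(N)=C(C#N)C(c3ccc(Cl)cc3Cl)C3=C2CC(C)(C)CC3=O)cc(OC)c1OC`, with 100%
- compound 2, `COc1ccccc1C1C(C#N)=C(N)N(c2cc(OC)c(OC)c(OC)c2)C2=C1C(=O)CC(C)(C)C2`, with 100%

In a functional assay on Ehrlich cells (Mus musculus) for cytotoxicity, tested at 100 ug/mL (a higher number here means a stronger effect of the compound at the concentration tested, a lower number a weaker effect), compound 1 gives 100%. Compound 2 gives 100%, so it stands level with compound 1 at the digits shown; the step of no change at the digits printed from compound 1 to compound 2 (within the scatter) lies within the scatter. That step swapped the whole aryl group on the saturated ring carbon of the shared core.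

Compound 3, `COc1cc(N2C(N)=C(C#N)C(c3ccccc3Cl)C3=C2CC(C)(C)CC3=O)cc(OC)c1OC`, differs from compound 2 at that same aryl group: chloro in place of methoxy on an aromatic carbon. Read one bond further out, this is 2-methoxyphenyl to 2-chlorophenyl. Among the compounds with values here, the single measured step bearing on it, from compound 1 to compound 2, was a larger exchange of the same aryl group and gave no change beyond the scatter. A step of a number 2 percentage points lower from compound 2 to compound 3 (within the scatter) is therefore expected for compound 3, with no change beyond the scatter. The value for compound 3 is estimated at 98%, in a range from 85% to 100%.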

Compound 3, a percentage reported as activity, at one concentration (the size of the read-out at that concentration, not a potency): 20%
Compound 3: middle estimate off by 78 percentage points, on the high side, and the stated range ends above it.
By their numbers in this assay, from the lowest: compound 3; then compounds 1 and 2 (each within the scatter of the next).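

In this assay, within the data shown here, the aryl group on the saturated ring carbon turns out to matter a great deal, which the first pair of compounds did not reveal. Chloro in place of methoxy gives a number 80 percentage points lower from compound 2 to compound 3 (beyond the scatter) and hydrogen in place of chloro gives a number 80 percentage points lower from compound 1 to compound 3 (beyond the scatter) so small edits at this one aryl group separate compound 3 from two compounds that otherwise read alike. No measurement here gives a reason for this drop.

On these data alone, whether other groups at this place on the aromatic ring, such as fluoro, hydroxyl or an amine, would read like compound 2 or like compound 3 remains open. A read-out at one concentration also cannot show whether compound 1 and compound 2 differ in potency.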